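The source may hold more compounds than are shown below. What is called first, only, known or untested is meant among the compounds shown, and "the series" means these compounds.

Measured so far in a toxicity assay on THP-1 cells (Homo sapiens) for inhibition; a higher number here means that more compound is tolerated, a lower number that less compound is tolerated (each entry is a limit, not a number):
- compound 1 `COc1ccc(-c2cnc(NC(=O)c3ccc(O)cc3)n2C)cc1` gives > 100000 nM
- compound 2 `COc1ccc(-c2cnc(NC(=O)C3CCCCC3)n2C)cc1` gives > 100000 nM
- compound 3 `COc1ccc(-c2cnc(NC(=O)C3CCOCC3)n2C)cc1` gives > 100000 nM

Compound 3 is known only as a limit, > 100000 nM, and it has no number of its own. It shares that position with the rest of the series, as the limit of > 100000 nM in this assay, at which 3 of the 3 values shown sit, shows.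

The next step leads to compound 4 `COc1ccc(-c2cnc(NC(=O)c3ccncc3)n2C)cc1` and is pyridin-4-yl in place of oxan-4-yl on a carbonyl carbon. In words, this is pyridin-4-yl in place of oxan-4-yl on a carbonyl carbon.

Three measured steps change the same place: a step that the two limits leave unreadable from compound 1 to compound 2, a step that the two limits leave unreadable from compound 1 to compound 3 and a step that the two limits leave unreadable from compound 2 to compound 3. None of them has a readable size, so they give no measure of how much this place matters in this assay. For the measured compounds named here, they show only that all three groups tried there end at the limit. The closest case for an aromatic ring at this place is compound 1, which is also a limit at > 100000 nM.

On that basis, no step beyond the scatter is expected, and the expected size is a number no higher from compound 3 to compound 4 (the limit leaves the size open). The assay will most likely report compound 4 as a limit too. For compound 4 the estimated value is 100000 nM, with an expected range from 40000 nM to 200000 nM.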

Compound 4, half-maximal cytotoxic concentration: > 100000 nM
Compound 4 was reported as a limit; the forecaster's own chance of this, stated with the estimate: 85%; the middle value sits exactly at the limit.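

In this assay, for the compounds shown here, compound 4 gives > 100000 nM, a limit and not a number, so no step from compound 1, compound 2 or compound 3 to compound 4 can be read. The series stands at one value: the limit of > 100000 nM in this assay, at which 4 of the 4 values shown sit.

The compounds shown leave open what concentration any of them takes to reach the half-maximal cytotoxic effect, and whether the group on the carbonyl carbon matters in this assay.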